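Acyl chain changes on the amide carbonyl: working notes

This account rests on a few compounds, and the source may have more. Where it says the series, first, only, none or still open, it means among the compounds named here.

Measured so far in a functional assay on HCT-116 cells (Homo sapiens) for inhibition, read by MTT assay, with a stated time of 48 h; a lower number here means a stronger inhibitor, a higher number a weaker inhibitor
compound 1 `COc1ccc(CN(C(=O)C=C(C)C)c2cc(OC)c(OC)c(OC)c2)cc1O` gives 290 nM
compound 2 `CCC/C=C/C(=O)N(Cc1ccc(OC)c(O)c1)c1cc(OC)c(OC)c(OC)c1` gives 95 nM

Compound 2 holds the lower of the two numbers, with compound 1 as its nearest neighbour. The change to compound 3 `COc1ccc(CN(C(=O)CCCCCl)c2cc(OC)c(OC)c(OC)c2)cc1O` is 4-chlorobutyl in place of pent-1-en-1-yl on a carbonyl carbon, and the shared core stays the same. Going by the values given here, the one measured step at this place is pent-1-en-1-yl in place of 2-methylprop-1-en-1-yl (a 3.1-fold lower number from compound 1 to compound 2 (0.48 log units; beyond the scatter)), which is modest and beyond the scatter. Among the compounds with values here, no measured compound carries chlorine or a chain without a double bond here, so the direction rests on little. Within the data shown here, compound 2 (95 nM) is the lower of only two values, so a modest rise in this assay is expected. The estimated step is of similar size (a 2.4-fold higher number from compound 2 to compound 3 (0.38 log units; beyond the scatter)). Compound 3 is estimated at 230 nM (expected range 70 nM to 800 nM).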

Compound 3, half-maximal inhibitory concentration: 220 nM
Estimate against measurement, compound 3: 1.0-fold (0.02 log units) above; measured number inside the range.
By their numbers in this assay, from the lowest: compound 2; then compounds 3 and 1 (each within the scatter of the next).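

In this assay, a chain with no double bond and with chlorine on it stays in the same range as the branched alkene: the step to the 4-chlorobutyl chain in compound 3 from the 2-methylprop-1-en-1-yl chain reads (a 1.3-fold lower number from compound 1 to compound 3 (0.12 log units; within the scatter)), while the step from the pent-1-en-1-yl chain is modest (a 2.3-fold higher number from compound 2 to compound 3 (0.36 log units; beyond the scatter)). Among the three acyl chains on this carbonyl carbon, only the pent-1-en-1-yl chain of compound 2 gives a number set apart from the other two by more than the scatter. No evidence bears on the cause of these differences.

The step removes the double bond and brings in chlorine at once, so a plain pentyl chain would be needed to read the two apart. Going by these compounds, how an amine in place of the chlorine, or a longer chain, would read also remains open.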